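This account rests on a few compounds, and the source may have more. Where it says the series, first, only, none or still open, it means among the compounds named here.

Three iminosugar compounds with a shared core carry a six-carbon chain that ends in an ether, and they were examined in an ADME assay on MDBK cells (Bos taurus) for cytotoxicity, read by MTT assay; a lower number here means that less compound is tolerated, a higher number that more compound is tolerated. Compound 1, `CC1CC(OCCCCCCN2C[C@H](O)[C@@H](O)[C@H](O)[C@H]2CO)CC(C)(C)C1`, is the only one of the three for which this assay returns a number: compound 1 gives 250000 nM. Compound 2, `OC[C@@H]1[C@@H](O)[C@H](O)[C@@H](O)CN1CCC#CCCOc1cc(F)ccc1F`, reaches a limit of the assay rather than a number, and compound 2 is recorded as > 500000 nM. Compound 3, `OC[C@@H]1[C@@H](O)[C@H](O)[C@@H](O)CN1CCCCCCOc1c(F)c(F)c(F)c(F)c1F`, likewise sits at a limit, and compound 3 is recorded as > 500000 nM. Among the measured compounds shown here, compound 1 therefore stands as the only measured value, while the other two compounds lie at the limit of > 500000 nM in this assay, at which 2 of the 3 values shown sit. The ether in compound 1 is joined to a saturated ring, and compound 4, `CC1CCC(OCCCCCCN2C[C@H](O)[C@@H](O)[C@H](O)[C@H]2CO)CC1C`, keeps everything else while altering that ring: a group of 8 heavy atoms (8 carbon; one six-membered non-aromatic ring of carbon only) in place of a group of 9 heavy atoms (9 carbon; one six-membered non-aromatic ring of carbon only), on an oxygen on a saturated carbon. For the measured compounds named here, no measured pair in this set shares such a change, so no step size can be read from the data. The change is a small rearrangement of carbon atoms on the ring, and the step from compound 1 to compound 4 in this assay is expected to remain within the usual scatter, as a 1.2-fold higher number from compound 1 to compound 4 (0.08 log units; within the scatter). Compound 4 is thus estimated to give 300000 nM, with the range running from 150000 nM to 600000 nM.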

Compound 4, half-maximal cytotoxic concentration: > 500000 nM
Compound 4 gave a limit, no number (the forecaster's own chance of this, stated with the estimate: 40%); middle value at least 1.6-fold (0.22 log units) away from the limit.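

Among the compounds shown here, exchanging the 3,3,5-trimethylcyclohexyl group for the ring of 8 carbon atoms, on an oxygen on a saturated carbon, gives the first step that can be read at this position: an at least 2.0-fold higher number from compound 1 to compound 4 (0.30 log units; that floor lies within the scatter). Since compound 4 reaches a limit and gives no number, this step is only a floor, and that floor does not lie beyond the usual scatter, so the result does not establish that this small change among carbon-only rings shifts tolerance in the cells at all. It does show that compound 1 is now the only compound of the four with a number, and that the carbon-only ring of compound 4 does not bring the value within the measurable range of the assay: the limit of > 500000 nM in this assay, at which 3 of the 4 values shown sit.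

On these data alone, how far compound 4 lies beyond its limit, and so the true size of the step, remains open. Also open, as far as these compounds go, is whether a ring carrying an amine or a carboxylic acid on that oxygen, or a longer chain to the shared core, would give a number that could be compared directly with that of compound 1.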